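This account rests on a few compounds, and the source may have more. Where it says the series, first, only, none or still open, it means among the compounds named here.

Measured compounds:
Compound 1, `COC(=O)C(C)(C)C(c1ccc(Nc2ccccc2)cc1)n1ccnc1`, gives 10 nM in an assay on microsomes from MCF7 cells for inhibition of cytochrome P450 26A1 (Homo sapiens), read by scintillation counting, with a stated time of 1 h; a lower number here means a stronger inhibitor, a higher number a weaker inhibitor.
Compound 2, `COC(=O)C(C)(C)C(c1ccc(Nc2cccc3ccccc23)cc1)n1ccnc1`, gives 6 nM in this assay.

For the measured compounds named here, only two numbers are known so far, and they sit close together: the step of a 1.7-fold lower number from compound 1 to compound 2 (0.22 log units; within the scatter) is within the scatter, so compound 2 and compound 1 cannot be told apart on these data, and neither can be called the stronger inhibitor.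

Compound 3, `COC(=O)C(C)(C)C(c1ccc(Nc2nc3ccccc3o2)cc1)n1ccnc1`, has not yet been measured. It differs from compound 2 in a single place: 1,3-benzoxazol-2-yl in place of naphthalen-1-yl on a nitrogen on an aromatic ring. Going by the values given here, the one measured step that bears on a change at this nitrogen is the step from compound 1 to compound 2, where a second six-membered carbon ring was added on the same nitrogen and the number moved by a 1.7-fold lower number from compound 1 to compound 2 (0.22 log units; within the scatter), within the scatter. Among the compounds with values here, the change to compound 3 keeps a two-ring group of about the same size at that position but brings in two hydrogen-bond acceptors, for which no measured step exists. On this basis, the step of a 1.3-fold higher number from compound 2 to compound 3 (0.12 log units; within the scatter) is expected to stay within the scatter. Compound 3 is therefore estimated at 8 nM, in the range 3 nM to 25 nM.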

Compound 3, half-maximal inhibitory concentration: 10 nM
Beside the measured number, compound 3's estimate is 1.3-fold (0.10 log units) below it; the range from low to high includes it.
By their numbers in this assay, from the lowest: compounds 2, 1 and 3 (each within the scatter of the next).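

In this assay, placing 1,3-benzoxazol-2-yl on the nitrogen in place of naphthalen-1-yl gives a 1.7-fold higher number from compound 2 to compound 3 (0.22 log units; within the scatter), while placing it there in place of phenyl gives no change at the digits printed from compound 1 to compound 3 (within the scatter). Until now, this nitrogen had carried only aromatic groups of carbon, so compound 3 extends the series to a group with a five-membered aromatic ring with 2 hetero atoms and with hydrogen-bond acceptors, and its number remains within the scatter of both earlier compounds. For the compounds shown here, the three groups therefore cannot be told apart here, and nothing measured so far separates a one-ring group from a two-ring group or a carbon-only group from one containing nitrogen and oxygen, while no other measurement bears on why the numbers lie so close together.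

The compounds shown leave open whether this insensitivity holds for a group without an aromatic ring on the nitrogen, such as a butyl chain or a piperidine ring. They also leave open how the number responds elsewhere in the molecule, for example with a carboxylic acid in place of the methyl ester shared by all three compounds.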